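Cycloheptyl in place of the aryl amide: cytotoxicity outlook

This account rests on a few compounds, and the source may have more. Where it says the series, first, only, none or still open, it means among the compounds named here.

Three oxalamide analogues built on one shared core have been tested in an ADME assay on TZM-b1 cells (Homo sapiens) for cytotoxicity, read by XTT assay, with a stated time of 3 days; on this read-out lower numbers stand for higher toxicity in this test and higher numbers for lower toxicity in this test. Compound 1 `Cc1nc(C(NC(=O)C(=O)Nc2ccc(Cl)cc2)C2CCCCN2)sc1CO` carries a 4-chlorophenyl group on an amide-type nitrogen. In this assay compound 1 reaches only a limit, > 22000 nM. Compound 2 `Cc1nc(C(NC(=O)C(=O)Nc2ccc(C(F)(F)F)cc2)C2CCCCN2)sc1CO` has trifluoromethyl in place of chloro on an aromatic carbon. In this assay compound 2 likewise stops at a limit, > 75500 nM. Compound 3 `Cc1ccc(NC(=O)C(=O)NC(c2nc(C)c(CO)s2)C2CCCCN2)cc1F` bears 3-fluoro-4-methylphenyl on the amide-type nitrogen. In this assay compound 3 again gives a limit, > 88000 nM. Compound 3 therefore stands among three limits, and no order can be set between them: the steps a step that the two limits leave unreadable from compound 1 to compound 2, a step that the two limits leave unreadable from compound 1 to compound 3 and a step that the two limits leave unreadable from compound 2 to compound 3 are all unreadable, as the limit of > 22000 nM in this assay, at which 1 of the 3 values shown sits, the limit of > 75500 nM in this assay, at which 1 of the 3 values shown sits, and the limit of > 88000 nM in this assay, at which 1 of the 3 values shown sits, show.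

Compound 4 `Cc1nc(C(NC(=O)C(=O)NC2CCCCCC2)C2CCCCN2)sc1CO` differs from compound 3 by cycloheptyl in place of 3-fluoro-4-methylphenyl on an amide-type nitrogen. Every measured step at this position concerned one aryl exchanged for another and none could be sized, so there is no measured basis for a step beyond the scatter. Compound 4 is accordingly expected to show a small step that the limit leaves unreadable from compound 3 to compound 4 in this assay. Compound 4 is estimated at 90000 nM, within 30000 nM to 200000 nM, most likely reported as a limit.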

Compound 4, half-maximal cytotoxic concentration: > 90000 nM
Compound 4: no number, only a limit; the forecaster's own chance of this, stated with the estimate: 75%; the middle value sits exactly at the limit.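

In this assay compound 4 gives > 90000 nM, which is again a limit. Its steps from compound 1, compound 2 and compound 3 therefore cannot be read. The compounds shown leave open where the half-maximal cytotoxic concentration of any of the four lies, and whether cycloheptyl and the aryl groups on the amide-type nitrogen differ at all.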